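Swapping phenyl for pyridin-4-yl on the fused core

The source may report more compounds than this note shows. Statements on the series, on what has been measured and on what is new or still open speak of the compounds shown alone.

Of the compounds shown here, two sharing the same sulfonamide-bearing core have been measured in a functional assay on KARPAS-422 cells (Homo sapiens) for inhibition, read by CCK-8 assay; a lower number here means a stronger inhibitor of growth, a higher number a weaker inhibitor of growth. Compound 1 `O=S(=O)(Nc1cc(-c2cnc3[nH]ncc3c2)cnc1Cl)c1ccccc1` gives 1090 nM in this assay. Compound 2 `O=S(=O)(Nc1cc(-c2cnc3[nH]cc(-c4ccccc4)c3c2)cnc1Cl)c1ccccc1` gives 1830 nM in this assay, a number that sits close to that of compound 1, with the gap between the two falling within the usual scatter, so neither can be called the stronger inhibitor on this evidence.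

Compound 3 `O=S(=O)(Nc1cc(-c2cnc3[nH]cc(-c4ccncc4)c3c2)cnc1Cl)c1ccccc1` differs from compound 2 in one place: pyridin-4-yl in place of phenyl on an aromatic carbon. Among the measured compounds shown here, no measured pair in this set shows what such a swap does, so there is no basis for expecting a step beyond the scatter in either direction. Compound 3 is therefore expected to land near compound 2, with the step of a 1.2-fold lower number from compound 2 to compound 3 (0.09 log units; within the scatter) expected to be small. Compound 3 is estimated at 1500 nM in this assay, within a range of 500 nM to 4500 nM.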

Compound 3, concentration for 50% growth inhibition: 120 nM
Compound 3: the middle estimate sits 13-fold (1.10 log units) above what was measured, outside the stated range (below it).
By their numbers in this assay, from the lowest: compound 3; then compounds 1 and 2 (each within the scatter of the next).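

In this assay, the aromatic carbon of the five-membered ring, two ring bonds from the ring nitrogen, turns out to be highly sensitive to which six-membered ring it carries: pyridin-4-yl in place of phenyl gives a 15-fold lower number from compound 2 to compound 3 (1.18 log units; beyond the scatter) on growth inhibition. The two groups have the same number of heavy atoms, and the exchange of one ring carbon for one nitrogen, which brings in one hydrogen-bond acceptor, is enough for a step of this size. Nothing available here accounts for the step.

The compounds shown leave open whether the ring nitrogen must sit where pyridin-4-yl places it, which pyridin-3-yl or pyridin-2-yl at this position would test. They also leave open whether a phenyl ring carrying an amine or a methoxy group would give a similar step.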